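The compounds below may be only part of what the source reports. "The series", "measured", "known", "first", "only" and "open" are said of these compounds alone.

Of the compounds shown here, three built on one shared core have been tested in a functional assay on the whole organism (B cells) with Mus musculus as the target; on this read-out lower numbers stand for smaller maximal responses and higher numbers for larger maximal responses. Compound 1 `C=CCn1c(=O)n(CCCCO)c2nc(N)nc(O)c21` gives 12% in this assay. Compound 2 `CCCCCCCCCCn1c(=O)n(C2OC(CO)[C@@H](O)[C@H]2O)c2nc(N)nc(O)c21` gives 0% in this assay. Compound 3 `C=CCn1c(=S)n(COCCO)c2nc(N)nc(O)c21` gives 9% in this assay. Among these, compound 2 carries the lowest of the three numbers. Its nearest neighbour is compound 3, whose number lies higher by an amount within the usual scatter of this kind of measurement, so the two cannot be ranked against each other. Compound 1 stands furthest away, higher by an amount beyond that scatter.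

Compound 4 `Cn1c(=O)n(C2OC(CO)[C@@H](O)[C@H]2O)c2nc(N)nc(O)c21` has not yet been measured. It differs from compound 2 in a single place: hydrogen in place of nonyl on a saturated chain carbon bound to an aromatic nitrogen. Among the compounds with values here, no pair of measured compounds shows a change of this kind, so no measured step is available to lean on. All three measured numbers are low, and even the gap between compound 2 and compound 1 only just exceeds the scatter. On that basis compound 4 is expected to remain in the same low region, with a step of a number 5 percentage points higher from compound 2 to compound 4 (within the scatter) expected to stay within the scatter, slightly upward if anything. Compound 4 is estimated to give 5% in this assay, with an expected range from 0% to 20%.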

Compound 4, largest response reached (reported as maximal response), in percent of the reference or control that the assay uses: 99%
The estimate for compound 4 lay 94 percentage points below the measured number; measured number above the stated range.
By their numbers in this assay, from the lowest: compounds 2, 3 and 1 (each within the scatter of the next, the first and the last beyond it); then compound 4.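

In this assay, within the data shown here, the single change of hydrogen in place of nonyl, on a saturated chain carbon bound to an aromatic nitrogen, comes with a number 99 percentage points higher from compound 2 to compound 4 (beyond the scatter). Read one bond further out, this is a change from decyl to methyl, and it shows that the length of the chain at this position can decide between almost no response and a large one, something the earlier compounds could not reveal, since they differ from one another in more than one place and offer no single-change step. Why shortening this chain has such a large effect cannot be said from what is available here.

Only the two extremes, methyl and decyl, are shown on this core, so it remains open whether the response fades gradually as the chain grows or collapses abruptly at some length, and a propyl or hexyl chain at this position would help to settle that. On these data alone, it also remains open whether the chain length alone matters or whether a chain ending in a hydroxyl or an amine would behave differently from a plain alkyl chain of the same length.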